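Hydroxyphenyl pyridines: cytotoxicity on HCT-15 cells

A few compounds are considered here, and "the series" means these few. Any claim that something is new, unique, unknown or untested is made for them only; others in the source may bear on it.

Measured so far:
compound 1, `Oc1ccc(-c2cc(-c3ccccn3)cc(-c3ccccc3O)n2)cc1`, > 50000 nM
compound 2, `Oc1ccc(-c2cc(-c3ccccn3)cc(-c3cccc(O)c3)n2)cc1`, > 50000 nM
compound 3, `Oc1ccccc1-c1cc(-c2cccnc2)cc(-c2ccccc2O)n1`, > 50000 nM

All three values come from a functional assay on HCT-15 cells (Homo sapiens) for cytotoxicity, read by CCK-8 assay; on this read-out higher numbers stand for weaker inhibition and lower numbers for stronger inhibition. For compound 1 the value > 50000 nM is a limit of the assay and not a number. For compound 2 the value > 50000 nM is likewise a limit. For compound 3 the value > 50000 nM is a limit as well. The three therefore sit at the same point: the limit of > 50000 nM in this assay, at which 3 of the 3 values shown sit.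

From compound 1 to compound 2 the change is 3-hydroxyphenyl in place of 2-hydroxyphenyl on an aromatic carbon, and the step it made is a step that the two limits leave unreadable from compound 1 to compound 2. The cores of compound 1 and compound 3 differ, but that difference is not broken down here.

Compound 4, `Oc1cccc(-c2cc(-c3cccnc3)cc(-c3ccccc3O)n2)c1`, is not yet measured in this assay. It is reached from compound 3 by 3-hydroxyphenyl in place of 2-hydroxyphenyl on an aromatic carbon. This is the same kind of change as that from compound 1 to compound 2, not the same: around the place it is meta to a 2-hydroxyphenyl group and meta to a pyridin-3-yl group, where in the earlier pair it was meta to a 4-hydroxyphenyl group and meta to a pyridin-2-yl group.

For compound 4 in this assay the expected step from compound 3 is a step that the limit leaves unreadable from compound 3 to compound 4, an expectation that rests on the earlier step that the two limits leave unreadable from compound 1 to compound 2 and on the limit at which compound 3 stands, > 50000 nM. The estimate for compound 4 is 70000 nM, expected to lie between 25000 nM and 300000 nM, most likely as a further limit.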

Compound 4, half-maximal inhibitory concentration: 8280 nM
The estimate for compound 4 lay 8.5-fold (0.93 log units) above the measured number; the whole stated range lies above it.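

In this assay, putting 3-hydroxyphenyl in place of 2-hydroxyphenyl on an aromatic carbon next to the ring nitrogen gives an at least 6.0-fold lower number from compound 3 to compound 4 (0.78 log units; beyond the scatter), so on the core of compound 3 this change brings a stronger inhibition, beyond the usual scatter. The same change on the core of compound 1 cannot be read, and no size can be set beside the new step, because both members of that earlier pair sit at the assay limit: the limit of > 50000 nM in this assay, at which 3 of the 4 values shown sit.
The series therefore shows that the change can matter on one core, but not that it carries over from one core to another, since a single readable pair gives neither a size that holds across cores nor a reason for the step.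

On these data alone, it remains open whether the step depends on the groups that stay around the place in compound 4, the 2-hydroxyphenyl group and the pyridin-3-yl group, or would also appear with the 4-hydroxyphenyl group and the pyridin-2-yl group of compound 2's core under a readable comparison. As far as these compounds go, it is also open whether the hydroxyl of the 3-hydroxyphenyl group is itself needed, as a 3-aminophenyl or 3-carboxyphenyl group in its place, or a longer chain such as 3-(2-hydroxyethyl)phenyl, would test.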